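Urea in place of amide on the shared core

The source may hold more compounds than are shown below. What is called first, only, known or untested is meant among the compounds shown, and "the series" means these compounds.

Of the compounds shown here, three on the shared core have been measured. Compound 1 `O=C(Nc1cccc(-n2cc(-c3ccncc3)c(-c3ccc(Cl)c(O)c3)n2)c1)Nc1ccc(Cl)c(Cl)c1` gives 1050 nM in a functional assay on OVCAR-3 cells (Homo sapiens) for inhibition, read by sulforhodamine B assay, with a stated time of 48 h; a lower number here means a stronger inhibitor, a higher number a weaker inhibitor. Compound 3 `O=C(Nc1cccc(-n2cc(-c3ccncc3)c(-c3ccc(Cl)c(O)c3)n2)c1)Nc1cc(C(F)(F)F)cc(C(F)(F)F)c1` gives 400 nM in this assay. Compound 2 `COc1cc(-c2nn(-c3cccc(NC(=O)c4ccc(Cl)c(C(F)(F)F)c4)c3)cc2-c2ccncc2)ccc1Cl` gives 2420 nM in this assay, the highest of the three numbers; its gap to compound 1 and its larger gap to compound 3 both lie beyond the scatter, so compound 2 is the weakest inhibitor of the three.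

Compound 4 `COc1cc(-c2nn(-c3cccc(NC(=O)Nc4cccc(C(F)(F)F)c4)c3)cc2-c2ccncc2)ccc1Cl` has not yet been measured. It differs from compound 2 in one place: (3-(trifluoromethyl)phenyl)amino in place of 4-chloro-3-(trifluoromethyl)phenyl on a carbonyl carbon. Among the measured compounds shown here, no pair of measured compounds differs in a single place, so no measured step sizes this kind of change directly. What the numbers do show is that compound 1 and compound 3, whose carbonyl carbon likewise bears an amino neighbour, both sit lower than compound 2.

The step from compound 2 to compound 4 is expected to be a 2.7-fold lower number from compound 2 to compound 4 (0.43 log units; beyond the scatter), toward a lower number and beyond the scatter, because compound 3 gives 400 nM and compound 1 gives 1050 nM. Compound 4 is therefore estimated at 900 nM, with a range from 350 nM to 2300 nM.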

Compound 4, half-maximal inhibitory concentration: 580 nM
Compound 4: middle estimate off by 1.6-fold (0.19 log units), on the high side; measured number inside the range.
By their numbers in this assay, from the lowest: compounds 3, 4 and 1 (each within the scatter of the next, the first and the last beyond it); then compound 2.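

In this assay, among the compounds shown here, the exchange on the carbonyl carbon gives a 4.2-fold lower number from compound 2 to compound 4 (0.62 log units; beyond the scatter) and is the first single-place step, so this position is now sized directly rather than inferred from compounds that differ elsewhere as well. The direction is toward the stronger inhibitor, and the step lies beyond the scatter, with (3-(trifluoromethyl)phenyl)amino, which carries a hydrogen-bond donor, replacing 4-chloro-3-(trifluoromethyl)phenyl, which carries none. Nothing measured here explains the shift.

The step joins two differences, the amino nitrogen that enters and the ring chlorine that leaves, and the compounds shown leave open how much of the step belongs to each; a pair with the same ring on both sides of the exchange would separate them. Also open, as far as these compounds go, is how the number would respond to a methylene or an oxygen in the place of that amino nitrogen on the carbonyl carbon.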